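Trading a Carboxy Group for Fluorine at One Aromatic Carbon

The source may hold more compounds than are shown below. What is called first, only, known or untested is meant among the compounds shown, and "the series" means these compounds.

Compound 2 `C=C1[C@@H](OC(C)=O)C[C@@H]2[C@](C)(CO[Si](C)(C)C(C)(C)C)[C@H](OC(C)=O)CC[C@@]2(C)[C@@H]1C[C@@H](Nc1ccc(C(=O)O)cc1)C1=CCOC1=O` and compound 1 `C=C1[C@@H](OC(C)=O)C[C@@H]2[C@](C)(CO[Si](C)(C)C(C)(C)C)[C@H](OC(C)=O)CC[C@@]2(C)[C@@H]1C[C@@H](Nc1ccc(OC)cc1)C1=CCOC1=O` share one core and differ only in a single group on the aromatic ring of the arylamine. In a functional assay on KB cells (Homo sapiens) for cytotoxicity, read by sulforhodamine B assay (a higher number here means a weaker inhibitor, a lower number a stronger inhibitor), compound 1 gives 5630 nM, and compound 2 gives 5540 nM. Compound 2 thus has the lowest of the two numbers, but its gap to compound 1 lies within the scatter, so the two cannot be told apart. Compound 3 `C=C1[C@@H](OC(C)=O)C[C@@H]2[C@](C)(CO[Si](C)(C)C(C)(C)C)[C@H](OC(C)=O)CC[C@@]2(C)[C@@H]1C[C@@H](Nc1ccc(F)cc1)C1=CCOC1=O` carries the change (fluoro in place of carboxy on an aromatic carbon). For the measured compounds named here, the one measured step that bears on it, a 1.0-fold lower number from compound 1 to compound 2 (0.01 log units; within the scatter), also swapped the group on that same aromatic carbon and left the number essentially unmoved. On that basis a step of similar size is expected, a 1.0-fold lower number from compound 2 to compound 3 (0.00 log units; within the scatter), meaning none beyond the scatter. Compound 3 is therefore estimated at 5500 nM in this assay, with a likely range from 2500 nM to 12000 nM.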

Compound 3, half-maximal inhibitory concentration: 5090 nM
Compound 3: middle estimate off by 1.1-fold (0.03 log units), on the high side; measured number inside the range.
By their numbers in this assay, from the lowest: compounds 3, 2 and 1 (each within the scatter of the next).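

Compound 3 puts a third group on this aromatic carbon, and it cannot be told apart from the other two: fluoro in place of carboxy gives a 1.1-fold lower number from compound 2 to compound 3 (0.04 log units; within the scatter), and fluoro in place of methoxy gives a 1.1-fold lower number from compound 1 to compound 3 (0.04 log units; within the scatter). In this assay, then, methoxy, carboxy and fluoro on this carbon, para to a large group, are not distinguished, even though carboxy has a hydrogen-bond donor and fluoro has none. Nothing shown here explains this result.

From the compounds shown here alone, whether an amine, a nitrile or a longer chain on the same carbon would also leave the number within the scatter remains open. Also open, going by these compounds, is whether a change elsewhere on the shared core would give a larger step in this assay.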